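Aryl amide variation on the shared core: clearance notes

The compounds below may be only part of what the source reports. "The series", "measured", "known", "first", "only" and "open" are said of these compounds alone.

Compound 1 `O=C(O)CCC(=O)N(C1CC1)[C@H]1c2ccccc2N(C(=O)c2ccc(OC(F)(F)F)cc2)[C@H]2CC[C@H]21` carries a 4-(trifluoromethoxy)phenyl on the carbonyl carbon of the shared core; in an ADME assay on cells (Hepatocyte, Rattus norvegicus) for metabolic stability (on this read-out higher numbers stand for fast clearance and lower numbers for slow clearance), compound 1 gives 13 uL/min. Compound 2 `O=C(O)COC(=O)N(C1CC1)[C@H]1c2ccccc2N(C(=O)c2ccc(F)cc2)[C@H]2CC[C@H]21` has a 4-fluorophenyl at that carbonyl carbon and differs from compound 1 elsewhere in the molecule as well; in this assay compound 2 gives 13 uL/min. Compound 1 therefore stands level with compound 2 at the digits shown, the gap lying within the usual scatter, so no ordering of the two is claimed.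

Compound 3 `O=C(O)CCC(=O)N(C1CC1)[C@H]1c2ccccc2N(C(=O)c2cccc(F)c2)[C@H]2CC[C@H]21` is the next member of the series. 3-fluorophenyl in place of 4-(trifluoromethoxy)phenyl on a carbonyl carbon The change sits on a carbonyl carbon whose other neighbour is an amide-type nitrogen in a ring. Within the data shown here, no measured pair in this set isolates that swap; the only comparison available, compound 1 against compound 2, shows two aryl variants at this carbonyl carbon with the same read-out within scatter.

On that basis the step of no change at the digits printed from compound 1 to compound 3 (within the scatter) is expected to be small, likely none beyond the scatter. Compound 3 is estimated at 13 uL/min in this assay, with a range from 7 uL/min to 26 uL/min.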

Compound 3, intrinsic clearance in a liver preparation (reported as CLH), per the amount of preparation that the assay uses: 16 uL/min
Beside the measured number, compound 3's estimate is 1.2-fold (0.09 log units) below it; the range from low to high includes it.
By their numbers in this assay, from the lowest: compounds 1, 2 and 3 (each within the scatter of the next).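

In this assay, among these compounds, placing 3-fluorophenyl in place of 4-(trifluoromethoxy)phenyl on the carbonyl carbon gives a 1.2-fold higher number from compound 1 to compound 3 (0.09 log units; within the scatter), and this is the first pair in the set that differs in that one place alone. At this position, a group of 11 heavy atoms with 1 hydrogen-bond acceptor and a group of 7 heavy atoms with 0 hydrogen-bond acceptors therefore cannot be told apart on this read-out, though this rests on a single pair and covers only these two groups. Nothing at hand speaks to the origin of this result.

As far as these compounds go, it remains open whether an aryl group carrying an amine or a carboxylic acid on this carbonyl carbon would also stay within the scatter of compound 1, or whether this position is insensitive only to neutral groups of the kind seen here. Also open, from the compounds shown here alone, is how a 4-fluorophenyl would read on the core of compound 1, a pairing that would separate the aryl change from the other difference that compound 2 carries elsewhere in the molecule.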